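From Compound 2 to an Altered Nitrooxy Ester Chain

A few compounds are considered here, and "the series" means these few. Any claim that something is new, unique, unknown or untested is made for them only; others in the source may bear on it.

This account concerns two measured compounds and one still to be tested in a functional assay on M14 cells (Homo sapiens) for cytotoxicity, read by resazurin assay, with a stated time of 72 h; a higher number here means a weaker inhibitor, a lower number a stronger inhibitor. Within the data shown here, compound 2 (`COc1cc(/C=C/C(=O)OCCCO[N+](=O)[O-])ccc1O`) gives 42600 nM, the only actual number available so far. Compound 1 (`COc1cc(/C=C/C(=O)OCCCO[N+](=O)[O-])ccc1OCCCO[N+](=O)[O-]`) reads > 50000 nM, which is a limit of this assay and not a number.

Compound 3 (`COc1cc(/C=C/C(=O)OC/C=C/CO[N+](=O)[O-])ccc1O`) departs from compound 2 at the ester side chain: a group of 7 heavy atoms (3 carbon, 1 nitrogen, 3 oxygen; no ring) in place of a group of 6 heavy atoms (2 carbon, 1 nitrogen, 3 oxygen; no ring), on a saturated chain carbon bound to an oxygen next to a carbonyl group. The new group sits on a saturated chain carbon bound to an oxygen next to a carbonyl group.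

Among the measured compounds shown here, only one measured step is available, an at least 1.1-fold lower number from compound 1 to compound 2 (0.06 log units; that floor lies within the scatter). It places hydrogen in place of 3-(nitrooxy)propyl on an oxygen on an aromatic ring, which is elsewhere in the molecule, and it does not go beyond the scatter. No measured step covers the ester side chain, so the data give no reason to expect a real shift in either direction. The expected change, a 1.3-fold lower number from compound 2 to compound 3 (0.11 log units; within the scatter), is therefore estimated to stay within the scatter. For compound 3 the estimated value is 33000 nM, with an expected range of 13000 nM to 50000 nM.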

Compound 3, half-maximal inhibitory concentration: 3890 nM
For compound 3 the middle estimate is 8.5-fold (0.93 log units) above the measured one; the whole stated range lies above it.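

In this assay, the ester side chain proves to be a place where the number responds strongly: the group with 2 double bonds outside aromatic rings, entering in place of 2-(nitrooxy)ethyl on a saturated chain carbon bound to an oxygen next to a carbonyl group, gives an 11-fold lower number from compound 2 to compound 3 (1.04 log units; beyond the scatter). The only earlier step, on an oxygen on an aromatic ring, had offered just a floor within the scatter, so this is the first change among the compounds shown that clearly goes beyond the scatter. Compound 1 stays outside any such size comparison, as its reading is a limit and not a number: the limit of > 50000 nM in this assay, at which 1 of the 3 values shown sits.

What remains open is which feature of the change matters, as the entering group differs from 2-(nitrooxy)ethyl both in its heavy atoms and in its double bonds outside aromatic rings, and the compounds shown do not separate the two. Also open, as far as these compounds go, is how a longer saturated chain such as 4-(nitrooxy)butyl, or a chain ending in a hydroxyl group in place of the nitrooxy group, would read at this place.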